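The source may report more compounds than this note shows. Statements on the series, on what has been measured and on what is new or still open speak of the compounds shown alone.

Measured so far: compound 1 `O=C(/N=C(/NC(=O)c1cc(-c2ccccc2)nc2ccccc12)[Se]Cc1ccccc1)c1cc(-c2ccccc2)nc2ccccc12`, which in a functional assay on HT-29 cells (Homo sapiens) for cytotoxicity, read by MTT assay, with a stated time of 72 h (on this read-out higher numbers stand for lower toxicity in this test and lower numbers for higher toxicity in this test), gives a limit of > 100000 nM. Compound 2 `O=C(/N=C(/NC(=O)c1cccs1)[Se]Cc1ccccc1)c1cccs1` in this assay also gives a limit, > 100000 nM. Compound 3 `CS/C(=N\C(=O)c1cccs1)NC(=O)c1cccs1` in this assay gives a limit as well, > 100000 nM.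

The difference between the core of compound 1 and the core of compound 2 is not broken down here. Compound 3 is reached from compound 2 by one change, (a group of 2 heavy atoms (1 carbon, 1 sulfur; no ring) in place of a group of 8 heavy atoms (7 carbon, 1 selenium; one six-membered aromatic ring of carbon only), on a carbon with a double bond to nitrogen), and the resulting step, a step that the two limits leave unreadable from compound 2 to compound 3, cannot be sized, as both values are limits. All three measured values sit at the same limit: the limit of > 100000 nM in this assay, at which 3 of the 3 values shown sit.

The unmeasured compound 4 `CS/C(=N\C(=O)c1cc(-c2ccccc2)nc2ccccc12)NC(=O)c1cc(-c2ccccc2)nc2ccccc12` is reached from compound 1 by the same change, (a group of 2 heavy atoms (1 carbon, 1 sulfur; no ring) in place of a group of 8 heavy atoms (7 carbon, 1 selenium; one six-membered aromatic ring of carbon only), on a carbon with a double bond to nitrogen). Since the limit of > 100000 nM in this assay, at which 3 of the 3 values shown sit, holds for every value shown, and the parallel step that the two limits leave unreadable from compound 2 to compound 3 gave no readable size, compound 4 is expected to stay at the limit, with an estimated step that the limit leaves unreadable from compound 1 to compound 4. The estimate for compound 4 in this assay is 150000 nM, expected to lie between 50000 nM and 500000 nM.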

Compound 4, concentration lethal to 50% of the cells: > 100000 nM
Compound 4 was reported as a limit; the forecaster's own chance of this, stated with the estimate: 85%; the middle value is on the limit's open side.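

Compound 4 gives > 100000 nM in this assay, which is a limit, so the step from compound 1 to compound 4 cannot be read, and neither can any other step here. Every value shown sits at one limit: the limit of > 100000 nM in this assay, at which 4 of the 4 values shown sit.

The compounds shown leave open whether methylsulfanyl and the selenium-containing group differ at all in this read-out, on either core.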